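Aminobenzyl in place of bromobenzyl on the shared core

The source may report more compounds than this note shows. Statements on the series, on what has been measured and on what is new or still open speak of the compounds shown alone.

Going by the values given here, compound 1 `NC1CCC(Nc2nc(NCc3ccc(Br)cc3)c3ncn(C4CCCC4)c3n2)CC1` is the weaker of the two measured members. In a functional assay on HCT-116 cells (Homo sapiens) for inhibition, with a stated time of 72 h (a higher number here means a weaker inhibitor, a lower number a stronger inhibitor), compound 1 gives 790 nM, the highest of the two numbers in hand; the nearest measured compound, compound 2 `NC1CCC(Nc2nc(NCc3ccc(-c4cccc(F)c4)nc3)c3ncn(C4CCCC4)c3n2)CC1`, gives 74 nM in this assay, and that gap lies beyond the scatter. Compound 2 differs from compound 1 in more than one place, so its value says only where the series has reached, not what any single change is worth.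

Compound 3 `Nc1ccccc1CNc1nc(NC2CCC(N)CC2)nc2c1ncn2C1CCCC1` has not yet been measured in this assay. It differs from compound 1 in one place: 2-aminophenyl in place of 4-bromophenyl on a saturated chain carbon bound to a nitrogen on an aromatic ring. No measured pair in the series isolates this change, so nothing shown here fixes its size or sign. The expectation is a small step in the weaker direction, from compound 1 to compound 3 in this assay amounting to a 1.9-fold higher number from compound 1 to compound 3 (0.28 log units; within the scatter), with the range kept wide. Compound 3 is therefore estimated at 1500 nM in this assay, between 400 nM and 6000 nM.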

Compound 3, half-maximal inhibitory concentration: 2300 nM
Compound 3: middle estimate off by 1.5-fold (0.19 log units), on the low side; low and high end bracket the measured number.
By their numbers in this assay, from the lowest: compound 2; then compound 1; then compound 3.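

In this assay, going by these compounds alone, the change from 4-bromophenyl to 2-aminophenyl, on a saturated chain carbon bound to a nitrogen on an aromatic ring, gives a 2.9-fold higher number from compound 1 to compound 3 (0.46 log units; beyond the scatter) and is the first single-place step read. It shows that this position responds to the group it carries, although the step is modest, and that this particular exchange, which brings in an amine with a hydrogen-bond donor and acceptor, moves the number in the weaker direction. No independent measurement is available to explain this step.

The step changes both the group and its numbered place on the ring, so the loss of bromine, the entry of the amine and the change of place cannot be separated with the compounds shown. As far as these compounds go, whether a chlorine, a methoxy group or a carboxylic acid on the same ring would keep the number near that of compound 1 or move it further in either direction remains open, as does whether any such effect would carry over to the extended group of compound 2.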